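A few compounds are considered here, and "the series" means these few. Any claim that something is new, unique, unknown or untested is made for them only; others in the source may bear on it.

Compound 1 `COC(=O)C1=C(C)NC(=O)NC1c1ccoc1`: 8%
Compound 2 `CC(=O)C1=C(C)NC(=O)NC1c1ccoc1`: 6%
Compound 3 `CCNC(=O)C1=C(C)NC(=O)NC1c1ccoc1`: 1%

In an assay on membranes from CHO cells for displacement of a labelled ligand from adenosine receptor A1 (Homo sapiens), read by scintillation counting, with a stated time of 60 min, tested at 1 uM (on this read-out lower numbers stand for less inhibition and higher numbers for more inhibition at the one concentration tested (going by the name of the read-out)), compound 3 gives the lowest of the three numbers, yet both gaps to its neighbours stay within the scatter: a number 5 percentage points lower from compound 2 to compound 3 (within the scatter) and a number 7 percentage points lower from compound 1 to compound 3 (within the scatter). Compound 4 `CCSC(=O)C1=C(C)NC(=O)NC1c1ccoc1` differs from compound 3 in one place: ethylsulfanyl in place of ethylamino on a carbonyl carbon. Among the measured compounds shown here, every measured step so far swaps the group on the same carbonyl carbon, and none moves the read-out beyond the scatter, as seen in a number 2 percentage points lower from compound 1 to compound 2 (within the scatter), a number 7 percentage points lower from compound 1 to compound 3 (within the scatter) and a number 5 percentage points lower from compound 2 to compound 3 (within the scatter). For the measured compounds named here, no measured step puts ethylsulfanyl in place of ethylamino, so this exact change is untested. The expected step is therefore small, a number 4 percentage points higher from compound 3 to compound 4 (within the scatter), within the scatter. Compound 4 is estimated at 5%, with a range from 0% to 15%.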

Compound 4, a percentage reported as inhibition, at one concentration (the size of the read-out at that concentration, not a potency): 3%
Compound 4: the middle estimate sits 2 percentage points above what was measured; measured number inside the range.
By their numbers in this assay, from the lowest: compounds 3, 4, 2 and 1 (each within the scatter of the next).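

Putting ethylsulfanyl on the carbonyl carbon swaps the nitrogen of ethylamino, with its hydrogen-bond donor, for sulfur, yet this assay shows a number 2 percentage points higher from compound 3 to compound 4 (within the scatter). The other two comparisons agree, with a number 3 percentage points lower from compound 2 to compound 4 (within the scatter) and a number 5 percentage points lower from compound 1 to compound 4 (within the scatter), so four different groups here cannot be told apart on this read-out. Nothing measured explains why these numbers sit so close together.

On these data alone, whether a carboxylic acid, an unsubstituted amide or a longer chain on this carbonyl carbon would give a clearly different number stays open. So does the effect of any change elsewhere on the shared core.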